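This account rests on a few compounds, and the source may have more. Where it says the series, first, only, none or still open, it means among the compounds named here.

Of the compounds shown here, two built on a shared core have been measured in a functional assay on CHO cells for agonist activity at Alpha-1A adrenergic receptor (Homo sapiens), read by FLIPR and calcium flux; a higher number here means a larger maximal response, a lower number a smaller maximal response. Compound 1 `c1ccc(-c2cccc3c2CCC3c2ncc[nH]2)nc1` gives 53%, the higher of the two results. Compound 2 `COc1c(C)ccc2c1CCC2c1ncc[nH]1` gives 40%, a result that lies beyond the usual scatter below that of compound 1, so compound 1 stands at the top of the pair. Compound 3 `Cn1ccc(-c2cccc3c2CCC3c2ncc[nH]2)n1` has not yet been measured. It differs from compound 1 in one place: 1-methyl-1H-pyrazol-3-yl in place of pyridin-2-yl on an aromatic carbon. Among the compounds with values here, no measured pair shows the effect of this kind of exchange, so the size of the step can only be judged roughly. The maximal response is expected to move only a little, with a small decrease as the more likely direction, so the expected step of a number 8 percentage points lower from compound 1 to compound 3 (within the scatter) stays close to the scatter. Compound 3 is therefore estimated to reach 45% in this assay, with a range from 25% to 68%.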

Compound 3, largest response reached (Emax), in percent of the reference or control that the assay uses: 19%
For compound 3 the middle estimate is 26 percentage points above the measured one; measured number outside the range, below it.
By their numbers in this assay, from the lowest: compound 3; then compound 2; then compound 1.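

Placing 1-methyl-1H-pyrazol-3-yl instead of pyridin-2-yl on this aromatic carbon gives a number 34 percentage points lower from compound 1 to compound 3 (beyond the scatter) in this assay. The maximal response at this position is therefore sensitive to the identity of the aromatic ring, even though the two groups have the same count of heavy atoms, carry no net charge and have no hydrogen-bond donors; they differ in ring size and in their hetero atoms. Nothing measured here explains this large loss of response.

The compounds shown leave open whether the loss goes with the five-membered ring, its second ring nitrogen or its methyl group, as no pair separates these features. From the compounds shown here alone, it also remains open how a plain phenyl ring, a pyridin-3-yl group or a dimethylamino group would behave on this same carbon.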